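This account rests on a few compounds, and the source may have more. Where it says the series, first, only, none or still open, it means among the compounds named here.

Compound 1, `CCCc1cnc(N2CCC(C3Cc4cc(C5=CCN(S(=O)(=O)CCC)CC5)ccc4O3)CC2)nc1`: 82 nM
Compound 2, `CCCc1cnc(N2CCC(C3Cc4cc(C5CCN(S(=O)(=O)CCC)CC5)ccc4O3)CC2)nc1`: 386 nM

In a functional assay on HEK293 cells for agonist activity at Glucose-dependent insulinotropic receptor (Homo sapiens), read by cAMP accumulation, with a stated time of 60 min (a higher number here means that more compound is needed for the effect, a lower number that less compound is needed), compound 1 holds the lower of the two numbers, the other lying a 4.7-fold higher number from compound 1 to compound 2 (0.67 log units; beyond the scatter). Compound 3, `CCCc1cnc(N2CCC(C3Cc4c(ccc(C5=CCN(S(=O)(=O)CCC)CC5)c4F)O3)CC2)nc1`, differs from compound 1 by fluoro in place of hydrogen on an aromatic carbon, the place being ortho to a fused ring and ortho to a large group. Among the measured compounds shown here, the single measured step swaps one ring-bearing group for another and says nothing about a fluoro entering here, so no step beyond the scatter is expected in this assay. Compound 3 is therefore estimated at 85 nM, within 30 nM to 250 nM, a step of a 1.0-fold higher number from compound 1 to compound 3 (0.02 log units; within the scatter).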

Compound 3, half-maximal effective concentration: 5 nM
The estimate for compound 3 lay 17-fold (1.23 log units) above the measured number; the whole stated range lies above it.
By their numbers in this assay, from the lowest: compound 3; then compound 1; then compound 2.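

In this assay, fluoro in place of hydrogen on this aromatic carbon, ortho to a fused ring and ortho to a large group, gives a 16-fold lower number from compound 1 to compound 3 (1.21 log units; beyond the scatter). This shows that a single fluorine at a position left unchanged between compound 1 and compound 2 can by itself produce a large step. Nothing available accounts for the size of this step.

From the compounds shown here alone, it remains open whether chloro or methyl on the same carbon would act as fluoro does. Going by these compounds, it also remains open whether fluoro would give a similar step on compound 2.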